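A few compounds are considered here, and "the series" means these few. Any claim that something is new, unique, unknown or untested is made for them only; others in the source may bear on it.

In a functional assay on the whole organism with Scenedesmus acutus as the target (a lower number here means a stronger inhibitor, a higher number a weaker inhibitor), the measured compounds stand as follows:
Compound 1 `O=C(O)c1cc(N2C(=O)C3=C(CCCC3)C2=O)c(F)cc1Cl` gives 759 nM
Compound 2 `O=C(O)c1cc(N2C(=O)C3=C(CCCC3)C2=O)ccc1Cl` gives > 100000 nM (a limit of the assay, not a number)
Compound 3 `COC(=O)c1cc(N2C(=O)C3=C(CCCC3)C2=O)ccc1Cl` gives 2000 nM

Compound 1 holds the lower of the two true numbers, and compound 3 is its nearest neighbour, with a gap beyond the scatter. The step now followed leads to compound 4 `CCOC(=O)c1cc(N2C(=O)C3=C(CCCC3)C2=O)c(F)cc1Cl` and consists of ethyl in place of hydrogen on an oxygen next to a carbonyl group so that carboxy becomes ethoxycarbonyl.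

The closest measured precedent is the step of an at least 50-fold lower number from compound 2 to compound 3 (1.69 log units; beyond the scatter) in which methyl takes the place of hydrogen on an oxygen next to a carbonyl group. The fluoro step an at least 130-fold higher number from compound 1 to compound 2 (2.11 log units; beyond the scatter) matters too, since it separates the two acids. Both steps were large, but both end on the limit of compound 2, so they give bounds rather than sizes. Ethyl is also not methyl, and compound 1 already starts far lower than compound 2. A clear move to a lower number is therefore expected in this assay with the estimated step of a 15-fold lower number from compound 1 to compound 4 (1.18 log units; beyond the scatter) as its size. Compound 4 is expected at 50 nM with an estimated range from 8 nM to 400 nM in this assay when measured.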

Compound 4, half-maximal inhibitory concentration: 100 nM
Compound 4: middle estimate off by 2.0-fold (0.30 log units), on the low side; measured number inside the range.
By their numbers in this assay, from the lowest: compound 4; then compound 1; then compound 3. At a limit, above all of these: compound 2.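

The earlier replacement on this oxygen, the step of an at least 50-fold lower number from compound 2 to compound 3 (1.69 log units; beyond the scatter), gave only a bound, since it starts from a limit and not from a number: the limit of > 100000 nM in this assay, at which 1 of the 4 values shown sits. In this assay, among the compounds shown here, the step of a 7.6-fold lower number from compound 1 to compound 4 (0.88 log units; beyond the scatter) is the first such replacement read between two true numbers, and its size is modest. It also shows that turning carboxy into ethoxycarbonyl still lowers the number when the acid is already measurable, so the lowering is not confined to an acid sitting at the limit.

The compounds shown leave open whether methyl on that oxygen would match ethyl on the core of compound 1, and whether a longer chain such as butyl, or an amide in place of the ester, would lower the number further. Going by these compounds, compound 3 and compound 4 differ in more than one place, so the share of the fluoro group among the esters also stays open.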